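A few compounds are considered here, and "the series" means these few. Any claim that something is new, unique, unknown or untested is made for them only; others in the source may bear on it.

Compound 1 `CC(=O)Nc1cn2cc(-c3cc(NC(=O)c4ccc(CN5CCN(C)CC5)c(C(F)(F)F)c4)ccc3C)ccc2n1` carries an amide whose aromatic part bears both a trifluoromethyl group and a (4-methylpiperazin-1-yl)methyl group. Within the data shown here, in a functional assay on A-375 cells (Homo sapiens) for antiproliferative activity (on this read-out lower numbers stand for an effect already at smaller amounts and higher numbers for an effect only at larger amounts of compound), compound 1 gives 430 nM, the highest of the three numbers measured so far. Compound 2 `CC(=O)Nc1cn2cc(-c3cc(NC(=O)c4ccccc4)ccc3C)ccc2n1`, with a plain phenyl on the carbonyl carbon, gives 100 nM in this assay, and compound 3 `CC(=O)Nc1cn2cc(-c3cc(NC(=O)c4cc(C(F)(F)F)ccn4)ccc3C)ccc2n1`, with 4-(trifluoromethyl)pyridin-2-yl in that position, gives 280 nM.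

Compound 4 `CC(=O)Nc1cn2cc(-c3cc(NC(=O)c4cccc(C(F)(F)F)c4)ccc3C)ccc2n1` is compound 1 with one change: hydrogen in place of (4-methylpiperazin-1-yl)methyl on an aromatic carbon. Among the measured compounds shown here, no measured pair shows exactly this change. For the measured compounds named here, the only single-point step available, a 2.8-fold higher number from compound 2 to compound 3 (0.45 log units; beyond the scatter), shows that swapping the aromatic group on the carbonyl carbon moves the number modestly but beyond the scatter. Compound 4 sits structurally between compound 1 and compound 2, keeping the trifluoromethyl group but losing the larger substituent. Because compound 2 gives 100 nM and compound 1 gives 430 nM, compound 4 is expected to land between them, which means an expected step of a 2.2-fold lower number from compound 1 to compound 4 (0.33 log units; beyond the scatter). For compound 4 the estimated value in this assay is 200 nM, with an expected range from 80 nM to 500 nM.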

Compound 4, half-maximal effective concentration in the A-375 assay: 86 nM
Estimate against measurement, compound 4: 2.3-fold (0.37 log units) above; low and high end bracket the measured number.
By their numbers in the A-375 assay, from the lowest: compounds 4 and 2 (each within the scatter of the next); then compounds 3 and 1 (each within the scatter of the next).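

In the A-375 assay, the (4-methylpiperazin-1-yl)methyl group, at this position para to a large group, is what separates the compounds: its replacement by hydrogen gives a 5.0-fold lower number from compound 1 to compound 4 (0.70 log units; beyond the scatter), and the 3-(trifluoromethyl)phenyl amide also stands clear of the pyridine amide, with a 3.3-fold lower number from compound 3 to compound 4 (0.51 log units; beyond the scatter), whereas adding the trifluoromethyl group to the plain phenyl amide gives only a 1.2-fold lower number from compound 2 to compound 4 (0.07 log units; within the scatter). The same position also matters for a second read-out, since in a physicochemical assay for solubility, in phosphate buffer, at pH 7 (a lower number here means a less soluble compound, a higher number a more soluble compound), compound 1, which carries the group, gives 4600 nM. In the physicochemical assay compound 4, with hydrogen in its place, gives < 400 nM, which is a limit of the assay and not a number, so the change reads as an at least 11-fold lower number from compound 1 to compound 4 (1.06 log units; beyond the scatter).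

From the compounds shown here alone, whether a smaller amine such as a dimethylaminomethyl group, or a morpholine ring, at this position would pair the number of compound 4 in the A-375 assay with the number of compound 1 in the physicochemical assay stays open. Also open is which part of the departing group, its ring or its nitrogen atoms, accounts for these steps, as the whole group leaves at once.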